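This account rests on a few compounds, and the source may have more. Where it says the series, first, only, none or still open, it means among the compounds named here.

Two compounds have been measured in a functional assay on 1321-N1 cells for agonist activity at P2Y purinoceptor 4 (Homo sapiens), read by scintillation counting and inositol phosphate accumulation; on this read-out lower numbers stand for an effect already at smaller amounts and higher numbers for an effect only at larger amounts of compound:

Compound 1 `O=c1[nH]/c(=N\OCCCc2ccc(F)cc2)ccn1[C@@H]1O[C@H](COP(=O)(O)OP(=O)(O)OP(=O)(O)O)[C@@H](O)[C@H]1O`: 105 nM
Compound 2 `O=c1[nH]/c(=N\OCCCc2ccc(Br)cc2)ccn1[C@@H]1O[C@H](COP(=O)(O)OP(=O)(O)OP(=O)(O)O)[C@@H](O)[C@H]1O`: 141 nM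

Compound 2 holds the higher of the two numbers, yet the step of a 1.3-fold higher number from compound 1 to compound 2 (0.13 log units; within the scatter) lies within the scatter. Compound 3 `O=c1[nH]/c(=N\OCCCc2cccnc2)ccn1[C@@H]1O[C@H](COP(=O)(O)OP(=O)(O)OP(=O)(O)O)[C@@H](O)[C@H]1O` differs from compound 2 by pyridin-3-yl in place of 4-bromophenyl on a saturated chain carbon, three bonds along the chain from an oxygen. Among the compounds with values here, the only measured step, from compound 1 to compound 2, swaps one halogen for another on that ring and stayed within the scatter; no measured step tests the ring itself. Compound 3 is therefore expected to show a 1.1-fold higher number from compound 2 to compound 3 (0.03 log units; within the scatter). The estimate for compound 3 is 150 nM, ranging from 50 nM to 500 nM.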

Compound 3, half-maximal effective concentration: 300 nM
Compound 3: the middle estimate sits 2.0-fold (0.30 log units) below what was measured, and the stated range covers the measured number.
By their numbers in this assay, from the lowest: compounds 1 and 2 (each within the scatter of the next); then compound 3.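

Exchanging the ring itself, rather than only its halogen, produces a step beyond the scatter in this assay: a 2.1-fold higher number from compound 2 to compound 3 (0.33 log units; beyond the scatter), and likewise a 2.9-fold higher number from compound 1 to compound 3 (0.46 log units; beyond the scatter). Both steps are modest, so the aromatic group on this saturated chain carbon does influence the number, whereas the halogen exchange did not move it beyond the scatter. Nothing available explains the shift.

The compounds shown leave open whether the shift follows the ring nitrogen or the missing halogen. An unsubstituted phenyl, pyridin-2-yl or pyridin-4-yl group at this place would help separate these possibilities.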